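The source may report more compounds than this note shows. Statements on the series, on what has been measured and on what is new or still open speak of the compounds shown alone.

In a functional assay on HCT-116 cells (Homo sapiens) for antiproliferative activity, read by MTT assay, with a stated time of 48 h (a lower number here means a stronger inhibitor, a higher number a weaker inhibitor), compound 1 `CC(CCO)n1cnc2c(Cl)nc(F)nc21` gives 19800 nM and compound 2 `CCCCCCC(CCO)n1cnc2c(Cl)nc(F)nc21` gives 9960 nM, two numbers within the scatter of each other, so compound 2 stands level with compound 1 on the data so far. Compound 3 `CC(C)(C)[Si](C)(C)OCC(CCO)n1cnc2c(Cl)nc(F)nc21` differs from compound 2 as follows: a group of 8 heavy atoms (6 carbon, 1 oxygen, 1 silicon; no ring) in place of a group of 5 heavy atoms (5 carbon; no ring), on a saturated chain carbon, two bonds along the chain from an aromatic nitrogen. Going by the values given here, only one measured step bears on this place, on a saturated chain carbon, two bonds along the chain from an aromatic nitrogen: pentyl in place of hydrogen gave a 2.0-fold lower number from compound 1 to compound 2 (0.30 log units; within the scatter). That single step shows little response in this assay to the group carried there, though it says nothing directly about a group holding silicon and oxygen. No step beyond the scatter is therefore expected, and the expected change is a 1.0-fold higher number from compound 2 to compound 3 (0.00 log units; within the scatter). For compound 3 the estimated value is 10000 nM, with an expected range from 4000 nM to 25000 nM.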

Compound 3, half-maximal inhibitory concentration: 7780 nM
The estimate for compound 3 lay 1.3-fold (0.11 log units) above the measured number; low and high end bracket the measured number.
By their numbers in this assay, from the lowest: compounds 3, 2 and 1 (each within the scatter of the next, the first and the last beyond it).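

In this assay, the group holding silicon and oxygen, placed on a saturated chain carbon, two bonds along the chain from an aromatic nitrogen, gives a 1.3-fold lower number from compound 2 to compound 3 (0.11 log units; within the scatter) when it replaces pentyl, so the two groups stand level at this place. Set against a hydrogen atom at the same place, it gives a 2.5-fold lower number from compound 1 to compound 3 (0.41 log units; beyond the scatter); this is the first step here to lie beyond the scatter, and it is modest, whereas the step from hydrogen to pentyl stayed within it. No supporting data bear on why this step appears.

Still open, as far as these compounds go, is whether the silicon and oxygen themselves matter here, or whether any group of similar heavy-atom count would serve. Also open, from the compounds shown here alone, is how an amine, a carboxylic acid or a longer chain would read at this place.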